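The source may report more compounds than this note shows. Statements on the series, on what has been measured and on what is new or still open speak of the compounds shown alone.

Of the compounds shown here, three built on one shared core have been tested in a functional assay on SN12C cells (Homo sapiens) for inhibition, read by sulforhodamine B assay, with a stated time of 48 h, tested at 10 uM; a lower number here means less inhibition, a higher number more inhibition at the concentration tested (going by the name of the read-out). Compound 1 `c1ccc2c(-c3cn4ccnc4c(-c4ccc5ncn(C6CCCCC6)c5c4)n3)cccc2c1` gives 11.7%. Compound 2 `Fc1ccc(-c2cn3ccnc3c(-c3ccc4ncn(C5CCCCC5)c4c3)n2)cc1` gives 3.97%, and compound 3 `Fc1ccccc1-c1cn2ccnc2c(-c2ccc3ncn(C4CCCCC4)c3c2)n1` gives 10.1%. Where compound 3 stands is simple: a number 1.6 percentage points lower from compound 1 to compound 3 (within the scatter) and a number 6.1 percentage points higher from compound 2 to compound 3 (within the scatter), so all three numbers lie within the usual scatter of one another, none of the three numbers can be called higher or lower than another, and the inhibition in this assay is level across the set at the concentration tested.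

Compound 4 `c1csc(-c2cn3ccnc3c(-c3ccc4ncn(C5CCCCC5)c4c3)n2)c1` has not yet been measured. Its change from compound 3 is thiophen-2-yl in place of 2-fluorophenyl on an aromatic carbon. Within the data shown here, every measured step so far swaps one aromatic group on the same aromatic carbon, and every one stayed within the scatter: a number 7.7 percentage points lower from compound 1 to compound 2 (within the scatter), a number 1.6 percentage points lower from compound 1 to compound 3 (within the scatter) and a number 6.1 percentage points higher from compound 2 to compound 3 (within the scatter). A further swap of an aromatic group at that carbon is therefore expected to move the number by no step beyond the scatter, in no particular direction. Compound 4 is estimated at 9%, between 0% and 20%. This means an expected a number 1.1 percentage points lower from compound 3 to compound 4 (within the scatter).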

Compound 4, a percentage reported as inhibition, at one concentration (the size of the read-out at that concentration, not a potency): 2.84%
For compound 4 the middle estimate is 6.2 percentage points above the measured one, within the range that was stated.
By their numbers in this assay, from the lowest: compounds 4, 2, 3 and 1 (each within the scatter of the next).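

Among these compounds, the thiophen-2-yl group brings a five-membered aromatic ring with a sulfur atom to this aromatic carbon, a kind of ring the earlier compounds did not have there. In this assay the change still leaves the number level with all three earlier groups (a number 7.3 percentage points lower from compound 3 to compound 4 (within the scatter) and a number 1.1 percentage points lower from compound 2 to compound 4 (within the scatter) and a number 8.9 percentage points lower from compound 1 to compound 4 (within the scatter)), so the flat picture now covers six-membered, fused and five-membered aromatic groups at this carbon. No measurement at hand offers an explanation for this level result.

Going by these compounds, all four compounds carry an aromatic ring at this carbon, so it remains open whether an amine, a carboxylic acid or a longer alkyl chain there would move the number beyond the scatter. On these data alone, the effect of changes elsewhere on the shared core also remains open.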